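The source may hold more compounds than are shown below. What is called first, only, known or untested is meant among the compounds shown, and "the series" means these compounds.

Compound 3 `c1ccc(CNC2CCN(CCCc3c[nH]c4ccc(-n5cnnc5)cc34)CC2)cc1` gives the highest number of the three measured compounds in an assay on CHO cells for agonist activity at 5-hydroxytryptamine receptor 1D (Homo sapiens), read by GTPgammaS binding (on this read-out lower numbers stand for an effect already at smaller amounts and higher numbers for an effect only at larger amounts of compound), at 7.6 nM. Compound 1 `COC[C@H](NC1CCN(CCCc2c[nH]c3ccc(-n4cnnc4)cc23)CC1)c1ccccc1` gives 0.9 nM, and compound 2 `OCCC(NC1CCN(CCCc2c[nH]c3ccc(-n4cnnc4)cc23)CC1)c1ccccc1` gives 5.1 nM. Compound 4 `NC(=O)OC[C@H](NC1CCN(CCCc2c[nH]c3ccc(-n4cnnc4)cc23)CC1)c1ccccc1` differs from compound 3 by (carbamoyloxy)methyl in place of hydrogen on a saturated chain carbon bound to an amine nitrogen and an aromatic carbon. Among the compounds with values here, two measured steps touch the same carbon: an 8.4-fold higher number from compound 1 to compound 3 (0.93 log units; beyond the scatter), and a 1.5-fold higher number from compound 2 to compound 3 (0.17 log units; within the scatter). Removing a substituent from this carbon thus raised the number clearly in one case and left it within the scatter in the other. The (carbamoyloxy)methyl of compound 4 is closer in shape to the methoxymethyl of compound 1 than to the 2-hydroxyethyl of compound 2, so a modest fall in number is expected, a 3.8-fold lower number from compound 3 to compound 4 (0.58 log units; beyond the scatter). For compound 4 the estimate is 2 nM, with a range from 0.7 nM to 6 nM.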

Compound 4, half-maximal effective concentration: 9.3 nM
Compound 4: the middle estimate sits 4.7-fold (0.67 log units) below what was measured; measured number outside the range, above it.
By their numbers in this assay, from the lowest: compound 1; then compounds 2, 3 and 4 (each within the scatter of the next).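

Adding (carbamoyloxy)methyl to this carbon gives a 1.2-fold higher number from compound 3 to compound 4 (0.09 log units; within the scatter) and so brings no gain over hydrogen, which the methoxymethyl of compound 1 did bring. With a 1.8-fold higher number from compound 2 to compound 4 (0.26 log units; within the scatter) as well, the 2-(carbamoyloxy)-1-phenylethyl group cannot be told apart from the 3-hydroxy-1-phenylpropyl group. Carbamoyl in place of methyl on the oxygen gives a 10-fold higher number from compound 1 to compound 4 (1.01 log units; beyond the scatter) and removes the whole advantage of compound 1, so a filled carbon is not enough: what sits on that oxygen matters.

Going by these compounds, whether an ethyl on that oxygen, or a free hydroxyl, keeps the low number stays open. No evidence here gives a reason for these numbers.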